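A few compounds are considered here, and "the series" means these few. Any claim that something is new, unique, unknown or untested is made for them only; others in the source may bear on it.

Measured in a functional assay on SW-620 cells (Homo sapiens); on this read-out higher numbers stand for weaker inhibition and lower numbers for stronger inhibition:

- Compound 1 `COc1cc(NC(C)CCCNC(=O)NOCc2ccccc2)c2ncccc2c1`: 20000 nM
- Compound 2 `COc1cc(NC(C)CCCNC(=O)N(CCO)CCO)c2ncccc2c1`: > 100000 nM (a limit of the assay, not a number)
- Compound 3 `COc1cc(NC(C)CCCNC(=O)NO)c2ncccc2c1`: 35000 nM

Compound 3 cannot be told apart from compound 1 on these numbers: the step is a 1.8-fold higher number from compound 1 to compound 3 (0.24 log units; within the scatter). Neither of the two can be ranked above the other.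

Compound 4 `CCOC(=O)NCCCC(C)Nc1cc(OC)cc2cccnc12` has not yet been measured. It carries ethoxy in place of hydroxyamino on a carbonyl carbon.

All three measured steps are changes to the group on this same carbonyl carbon, although none of them introduces ethoxy. The exchange between compound 1 and compound 3 made no difference beyond the scatter. Compound 2 goes against any idea that this position tolerates every group, with an at least 5.0-fold higher number from compound 1 to compound 2 (0.69 log units; beyond the scatter) and an at least 2.8-fold lower number from compound 2 to compound 3 (0.45 log units; beyond the scatter), both beyond the scatter. Ethoxy is a small group, and it shares neither the bis(2-hydroxyethyl)amino group of compound 2 nor an obvious direction of change, so no step beyond the scatter is the best guess, with some risk of a weaker result.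

The expected step is a 1.2-fold lower number from compound 3 to compound 4 (0.07 log units; within the scatter). Compound 4 is estimated at 30000 nM, with an expected range of 10000 nM to 100000 nM.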

Compound 4, half-maximal inhibitory concentration: 45000 nM
Compound 4: the middle estimate sits 1.5-fold (0.18 log units) below what was measured; the measured number falls inside the stated range.
By their numbers in this assay, from the lowest: compounds 1, 3 and 4 (each within the scatter of the next, the first and the last beyond it). At a limit, above all of these: compound 2.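

In this assay, ethoxy, with 0 hydrogen-bond donors, cannot be told apart from hydroxyamino, with 2: a 1.3-fold higher number from compound 3 to compound 4 (0.11 log units; within the scatter). So among these compounds, the donors of hydroxyamino are not what sets the level of inhibition. Ethoxy can, however, be separated from (benzyloxy)amino, with a 2.3-fold higher number from compound 1 to compound 4 (0.35 log units; beyond the scatter), yet compound 3 lies within the scatter of both compound 1 and compound 4, so these three form a shallow run and not clearly separate levels. Ethoxy also stands apart from bis(2-hydroxyethyl)amino, with an at least 2.2-fold lower number from compound 2 to compound 4 (0.34 log units; beyond the scatter), a step that starts from a limit of the assay and not from a number: the limit of > 100000 nM in this assay, at which 1 of the 4 values shown sits.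

The compounds shown cannot tell whether the oxygen of ethoxy matters or only its size, and a plain ethyl group or a methoxy group on this carbonyl carbon would help to separate the two. Nor do they show whether a simple amine or a longer chain such as butoxy would stay in the same run or fall away as compound 2 does.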